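Anilide ring substitution and mouse microsomal clearance

The compounds below may be only part of what the source reports. "The series", "measured", "known", "first", "only" and "open" are said of these compounds alone.

Measured so far:
compound 1 `CN1C[C@H](C(=O)Nc2ccccc2)[C@@H](c2ccc(/C=C/C(=O)Nc3ccccc3N)cc2)C1`: 67 mL/min/kg
compound 2 `COc1ccc(NC(=O)[C@H]2CN(C)C[C@@H]2c2ccc(/C=C/C(=O)Nc3ccccc3N)cc2)cc1`: 54 mL/min/kg

In an in vitro ADME assay on microsomes from liver (Mus musculus) for pharmacokinetics, read by LC-MS, with a stated time of 10 min, tested at 1 uM (on this read-out higher numbers stand for fast clearance and lower numbers for slow clearance), compound 1 gives 67 mL/min/kg, the highest of the two numbers, yet compound 2 at 54 mL/min/kg lies within the scatter of it: a 1.2-fold lower number from compound 1 to compound 2 (0.09 log units; within the scatter). The two values therefore show no distinction on this read-out.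

Compound 3 `CN1C[C@H](C(=O)Nc2ccc(Cl)cc2F)[C@@H](c2ccc(/C=C/C(=O)Nc3ccccc3N)cc2)C1` is still unmeasured. It differs from compound 1 in one place: 4-chloro-2-fluorophenyl in place of phenyl on an amide-type nitrogen. For the measured compounds named here, the only measured step that bears on it is the one from compound 1 to compound 2, which changed the same aromatic ring and was within the scatter, a 1.2-fold lower number from compound 1 to compound 2 (0.09 log units; within the scatter). Going by the values given here, no step with a chlorine or fluorine substituent has been measured, so the expectation rests on the scatter alone.

On that basis no step beyond the scatter is expected in this assay, a 1.1-fold lower number from compound 1 to compound 3 (0.03 log units; within the scatter). For compound 3 the estimate is 62 mL/min/kg, with a range from 35 mL/min/kg to 110 mL/min/kg.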

Compound 3, clearance: 43 mL/min/kg
Compound 3: the middle estimate sits 1.4-fold (0.16 log units) above what was measured; the measured number falls inside the stated range.
By their numbers in this assay, from the lowest: compounds 3, 2 and 1 (each within the scatter of the next).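

In this assay, 4-chloro-2-fluorophenyl on the amide-type nitrogen stays within the scatter of phenyl (a 1.6-fold lower number from compound 1 to compound 3 (0.19 log units; within the scatter)). It also stays within the scatter of 4-methoxyphenyl at this position (a 1.3-fold lower number from compound 2 to compound 3 (0.10 log units; within the scatter)). This position therefore now carries a halogen-bearing aryl group as well as the methoxy-bearing one, and the read-out separates none of the three compounds; nothing on hand accounts for these numbers.

Still open, on these data alone, is whether the chlorine and the fluorine would read the same taken singly, since compound 3 carries both together. Also open, as far as these compounds go, is whether a carboxylic acid or an amine on this ring, or a cyclohexyl group in place of the ring, would give a step beyond the scatter.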